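Working notes: stepping from compound 1 to compound 4

This account rests on a few compounds, and the source may have more. Where it says the series, first, only, none or still open, it means among the compounds named here.

Measured in a functional assay on ECa-109 cells (Homo sapiens) for antiproliferative activity, read by MTT assay, with a stated time of 72 h; on this read-out higher numbers stand for weaker inhibition and lower numbers for stronger inhibition:
compound 1 `CCCSc1nc(N/N=C/c2ccccc2Cl)c2nnn(Cc3ccccc3)c2n1`: 6180 nM
compound 2 `CCCSc1nc(N/N=C/c2cc(OC)c(OC)c(OC)c2)c2nnn(Cc3ccccc3)c2n1`: 4060 nM
compound 3 `CCCSc1nc(N/N=C/c2c[nH]c3ccccc23)c2nnn(Cc3ccccc3)c2n1`: 8690 nM

Compound 1, at 6180 nM, lies within the scatter of both compound 2 and compound 3, so it gives no clear place in a ranking of the three. The next compound to be tested in this assay is compound 4 `CCCSc1nc(N/N=C(\C)c2ccccc2)c2nnn(Cc3ccccc3)c2n1`. The structural change is a group of 9 heavy atoms (8 carbon, 1 nitrogen; one six-membered aromatic ring of carbon only) in place of a group of 9 heavy atoms (7 carbon, 1 nitrogen, 1 chlorine; one six-membered aromatic ring of carbon only), on a nitrogen on an aromatic ring. Going by the values given here, no measured step tests this exact exchange. The closest evidence is a 1.4-fold higher number from compound 1 to compound 3 (0.15 log units; within the scatter), where 1H-indol-3-yl takes the place of 2-chlorophenyl on a carbon with a double bond to nitrogen. That single step is the only one available, and it stays within the scatter. The values of compound 1 and compound 2 also stay within the scatter of each other. No step beyond the scatter is therefore expected, and no direction can be called with any confidence. The expected step is a 1.1-fold higher number from compound 1 to compound 4 (0.02 log units; within the scatter). For compound 4 the estimated value is 6500 nM, with an expected range from 3000 nM to 14000 nM.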

Compound 4, half-maximal inhibitory concentration: 32200 nM
The estimate for compound 4 lay 5.0-fold (0.69 log units) below the measured number; measured number outside the range, above it.
By their numbers in this assay, from the lowest: compounds 2, 1 and 3 (each within the scatter of the next, the first and the last beyond it); then compound 4.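

In this assay, going by these compounds alone, the group on the nitrogen gives the first step beyond the scatter, with a 5.2-fold higher number from compound 1 to compound 4 (0.72 log units; beyond the scatter) set against a 1.4-fold higher number from compound 1 to compound 3 (0.15 log units; within the scatter) for the earlier exchange, which stayed within it. The group is therefore not indifferent to change: the exchange removes the chlorine and adds one carbon as a methyl, and this combined change separates compound 4 from compound 1 by more than the scatter. Nothing at hand accounts for the size or direction of this step.

Within the data shown here, a single step cannot show whether the loss of the chlorine or the gain of the methyl carries the shift, and a compound with only one of these changes would separate them. Also open, going by these compounds, is how this position would read with an amine or a carboxylic acid in the group.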